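The compounds below may be only part of what the source reports. "The series", "measured", "known", "first", "only" and "open" are said of these compounds alone.

Compound 1 `Nc1n[nH]c2cc(-c3ccc(=O)n(Cc4cccc(Cl)c4)c3)cc(NCC3CCOCC3)c12` gives 4 nM in an assay on isolated protein for inhibition of MAP kinase-interacting serine/threonine-protein kinase 1 (Homo sapiens); a higher number here means a weaker inhibitor, a lower number a stronger inhibitor. Compound 2 `CC(=O)N1CCC(CNc2cc(-c3ccc(=O)n(Cc4cccc(Cl)c4)c3)cc3[nH]nc(N)c23)CC1` gives 5 nM in this assay; the step of a 1.3-fold higher number from compound 1 to compound 2 (0.10 log units; within the scatter) is within the scatter, so compound 2 has the highest of the two numbers but is not separated from compound 1. Compound 3 `Nc1n[nH]c2cc(-c3ccc(=O)n(Cc4cccc(Cl)c4)c3)cc(OCC3CCOCC3)c12` differs by (oxan-4-yl)methoxy in place of ((1-acetylpiperidin-4-yl)methyl)amino on an aromatic carbon. For the measured compounds named here, only the step from compound 1 to compound 2 bears on this, and it changed the ring, not the linker; the change of linker is untested. A step of a 1.6-fold higher number from compound 2 to compound 3 (0.20 log units; within the scatter) is expected, probably within the scatter. Compound 3 is estimated at 8 nM, range 2 nM to 30 nM.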

Compound 3, half-maximal inhibitory concentration: 6 nM
Compound 3: middle estimate off by 1.3-fold (0.12 log units), on the high side; the measured number falls inside the stated range.
By their numbers in this assay, from the lowest: compounds 1, 2 and 3 (each within the scatter of the next).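

On the aromatic carbon, the linker itself now varies: in this assay, (oxan-4-yl)methoxy in place of ((oxan-4-yl)methyl)amino gives a 1.5-fold higher number from compound 1 to compound 3 (0.18 log units; within the scatter), so the two linkers are not separated. (oxan-4-yl)methoxy in place of ((1-acetylpiperidin-4-yl)methyl)amino, which goes from 1 hydrogen-bond donor to 0, gives a 1.2-fold higher number from compound 2 to compound 3 (0.08 log units; within the scatter), again without separation. No available evidence explains this tolerance. Open is whether a free piperidine amine, a carboxylic acid or a longer chain on this aromatic carbon would stay within the scatter of these compounds.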